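The source may report more compounds than this note shows. Statements on the series, on what has been measured and on what is new or still open speak of the compounds shown alone.

Measured compounds:
compound 1 `Cn1nc(Cc2nnc(SCC(=O)Nc3ccc(Cl)cc3Cl)n2CCC=O)c2ccccc2c1=O` gives 6000 nM in an assay on 32D cells for inhibition of interleukin-15 (Mus musculus), read by resazurin assay, with stated times of 30 min and 2.5 days, in the presence of a further agent that is not named here; on this read-out higher numbers stand for weaker inhibition and lower numbers for stronger inhibition;
compound 2 `Cn1nc(Cc2nnc(SCC(=O)Nc3ccc(Cl)cc3Cl)n2CCCO)c2ccccc2c1=O` gives > 30000 nM in this assay, a value that is a limit of the assay rather than a number;
compound 3 `Cn1c(Cc2nn(CCC=O)c(=O)c3ccccc23)nnc1SCC(=O)Nc1ccc(Cl)cc1Cl` gives 30000 nM in this assay.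

Compounds 1 and 3 are built from the same atoms joined differently; the difference between the two cores is not broken down here. Compound 3 stands at the higher number of the two.

One structural change appears twice among these compounds. From compound 1 to compound 2 it reads (hydroxymethyl in place of formyl on a saturated chain carbon, two bonds along the chain from an aromatic nitrogen), and the step it made was an at least 5.0-fold higher number from compound 1 to compound 2 (0.69 log units; beyond the scatter). The same change carries compound 3 to compound 4 `Cn1c(Cc2nn(CCCO)c(=O)c3ccccc23)nnc1SCC(=O)Nc1ccc(Cl)cc1Cl`, which is yet to be measured: hydroxymethyl in place of formyl on a saturated chain carbon, two bonds along the chain from an aromatic nitrogen.

Since compound 3 already sits at 30000 nM and the measured step of an at least 5.0-fold higher number from compound 1 to compound 2 (0.69 log units; beyond the scatter) pointed toward weaker inhibition, compound 4 is expected to move in the same direction, with a step estimated at a 3.3-fold higher number from compound 3 to compound 4 (0.52 log units; beyond the scatter). Compound 4 is therefore estimated at 100000 nM, between 30000 nM and 300000 nM, and it is expected most likely to be reported only as a limit.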

Compound 4, half-maximal inhibitory concentration: > 30000 nM
Compound 4: only a limit was reported (the forecaster's own chance of this, stated with the estimate: 85%); the middle value lies beyond the limit too.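

Putting hydroxymethyl in place of formyl gave a number no lower from compound 3 to compound 4 (the limit leaves the size open) in this assay. The change did not lower the number on either core, and the two results can be set side by side: the same change on two cores in this assay, an at least 5.0-fold higher number (0.69 log units; beyond the scatter) from compound 1 to compound 2 and a number no lower (the limit leaves the size open) from compound 3 to compound 4; the limit leaves it open whether they differ. Compound 4 gives > 30000 nM, which is a limit of the assay and not a number, so the size of its step cannot be read. The result is therefore consistent with the change carrying over in the same direction, but it does not show that the change costs the same amount on both cores, and the limit recurs in this small set: the limit of > 30000 nM in this assay, at which 2 of the 4 values shown sit.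

Going by these compounds, only formyl and hydroxymethyl appear at the end of this chain, so the effect of an amine, a carboxylic acid or a longer chain remains open on both cores. On these data alone, whether any of these would give a lower number than formyl on the core of compound 1 is equally open.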